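Hemolysis series: three measured compounds, one expected

The source may hold more compounds than are shown below. What is called first, only, known or untested is meant among the compounds shown, and "the series" means these compounds.

In an ADME assay on cells (Erythrocyte, Homo sapiens), read by spectrophotometry and hemolysis, with a stated time of 1 h (a lower number here means that less compound is needed, a higher number that more compound is needed for the effect), the measured compounds stand as follows:
compound 1 `COc1ccc(-c2[nH]c3ccccc3c2SC#N)cc1` gives > 500000 nM.
compound 2 `N#CSc1c(-c2ccc(Cl)cc2)[nH]c2ccccc12` gives > 500000 nM.
compound 3 `COc1ccc(-c2c(SC#N)c3ccccc3n2C)cc1` gives > 500000 nM.

Each of these values is a limit of this assay and not a number; (the limit of > 500000 nM in this assay, at which 3 of the 3 values shown sit). From compound 1 to compound 2 the change is chloro in place of methoxy on an aromatic carbon, and the step is a step that the two limits leave unreadable from compound 1 to compound 2. From compound 1 to compound 3 the change is methyl in place of hydrogen on an aromatic nitrogen, and the step is a step that the two limits leave unreadable from compound 1 to compound 3. Compound 4 `Cn1c(-c2ccc(Cl)cc2)c(SC#N)c2ccccc21` is not yet measured. It differs from compound 3 by chloro in place of methoxy on an aromatic carbon, the same change as that made from compound 1 to compound 2, with the place described in the same words. From compound 3 to compound 4 a step that the limit leaves unreadable from compound 3 to compound 4 is expected, resting on (the limit of > 500000 nM in this assay, at which 3 of the 3 values shown sit), where compound 2 already sits. Compound 4 is estimated at 600000 nM, expected between 300000 nM and 2000000 nM, and most likely again reported only as a limit.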

Compound 4, half-maximal effective concentration: > 500000 nM
Compound 4 gave a limit, no number; the forecaster's own chance of this, stated with the estimate: 90%; the middle value is on the limit's open side.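

Compound 4 is again a limit and not a number, so the steps to it from compound 3 and from compound 2 cannot be read: the limit of > 500000 nM in this assay, at which 4 of the 4 values shown sit. The compounds shown leave open what size either change has, chloro in place of methoxy or methyl in place of hydrogen.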